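Chain extension with ring fluorination in the carbamate series

The source may hold more compounds than are shown below. What is called first, only, known or untested is meant among the compounds shown, and "the series" means these compounds.

Compound 1 `COc1ccc(CCOC(=O)N(c2ccccc2)C2CN3CCC2CC3)cc1` gives 230 nM in an assay on CHO cells for displacement of a labelled ligand from muscarinic acetylcholine receptor M5 (Homo sapiens), read by scintillation counting, with a stated time of 2 h (a higher number here means a weaker inhibitor, a lower number a stronger inhibitor), the second highest of the three numbers recorded. Compound 2 `Cc1ccc(CCCOC(=O)N(c2ccccc2)C2CN3CCC2CC3)cc1F` gives 130 nM, and the step of a 1.8-fold lower number from compound 1 to compound 2 (0.25 log units; within the scatter) stays within the scatter. Compound 3 `COc1ccc(CCCOC(=O)N(c2ccccc2)C2CN3CCC2CC3)cc1OC` gives 1610 nM; the step of a 12-fold higher number from compound 2 to compound 3 (1.09 log units; beyond the scatter) is large and beyond the scatter.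

Compound 4 `O=C(OCCCc1ccc(F)c(F)c1)N(c1ccccc1)C1CN2CCC1CC2` has not been measured in this assay. Relative to compound 1 the change is 3,4-difluorobenzyl in place of 4-methoxyphenyl on a saturated chain carbon, two bonds along the chain from an oxygen next to a carbonyl group. The most relevant comparison is the step from compound 1 to compound 2, which also lengthens the chain by one carbon and replaces the 4-methoxyphenyl with a fluorinated ring, and which stayed within the scatter. The step from compound 2 to compound 3 shows that two methoxy groups on the ring carry a large penalty, but compound 4 carries two fluorines and no methoxy, so that step does not bear directly on it.

Compound 4 is therefore expected to sit close to compound 1 and compound 2, with a step of a 1.4-fold lower number from compound 1 to compound 4 (0.13 log units; within the scatter) that is not expected to exceed the scatter. The estimate for compound 4 is 170 nM, in the range 70 nM to 400 nM.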

Compound 4, inhibition constant: 100 nM
Beside the measured number, compound 4's estimate is 1.7-fold (0.23 log units) above it; measured number inside the range.
By their numbers in this assay, from the lowest: compounds 4, 2 and 1 (each within the scatter of the next, the first and the last beyond it); then compound 3.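

In this assay, 3,4-difluorobenzyl in place of 4-methoxyphenyl on a saturated chain carbon, two bonds along the chain from an oxygen next to a carbonyl group, gives a modest step that clears the scatter, a 2.3-fold lower number from compound 1 to compound 4 (0.36 log units; beyond the scatter), whereas 3-fluoro-4-methylbenzyl at the same place stayed within it, a 1.8-fold lower number from compound 1 to compound 2 (0.25 log units; within the scatter). With the chain held constant, 3,4-difluorophenyl in place of 3,4-dimethoxyphenyl gives a large step, a 16-fold lower number from compound 3 to compound 4 (1.21 log units; beyond the scatter), so this chain length does not by itself carry the high number of compound 3. Fluoro in place of methyl on an aromatic carbon is not resolved, since the step of a 1.3-fold lower number from compound 2 to compound 4 (0.11 log units; within the scatter) stays within the scatter.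

No data on hand explain why the ring groups differ in this way. As far as these compounds go, the steps from compound 1 combine a change in chain length with a change in the ring, so their separate contributions remain open, as does whether a longer chain, or a nitrile or trifluoromethyl on the ring, would hold the number near that of compound 4.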